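The compounds below may be only part of what the source reports. "The series", "measured", "known", "first", "only" and "open" are said of these compounds alone.

For the measured compounds named here, compound 3, whose structure is `O=C(CSC(=S)N[C@H]1CCOC1=O)Nc1ccc(C(=O)/C=C/c2ccc(Cl)cc2)cc1`, stands apart among the three measured compounds: in a functional assay on EC9706 cells (Homo sapiens) for cytotoxicity, read by MTT assay, with a stated time of 72 h (on this read-out lower numbers stand for stronger inhibition and higher numbers for weaker inhibition), compound 3 gives 38900 nM, the only actual number in the set. Compound 1, with the structure `O=C(CSC(=S)N[C@H]1CCOC1=O)Nc1ccccc1`, reaches only the limit of the assay at > 128000 nM. Compound 2, with the structure `O=C(CSC(=S)N[C@H]1CCOC1=O)Nc1ccc(O)cc1`, likewise gives only the limit > 128000 nM. Going by the values given here, the one measured step between these two, a step that the two limits leave unreadable from compound 1 to compound 2, therefore cannot be sized, and the same applies to the fact recorded as the limit of > 128000 nM in this assay, at which 2 of the 3 values shown sit.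

Compound 4, the unmeasured compound with the structure `O=C(CSC(=S)N[C@H]1CCOC1=O)Nc1ccc(C(=O)/C=C/c2ccccc2)cc1`, differs from compound 3 by hydrogen in place of chloro on an aromatic carbon. Among the compounds with values here, no measured step bears on this change: the only step on record joins compound 1 and compound 2 and is unreadable, and no pair in the set trades chloro for hydrogen anywhere. The change is small, touching a single heavy atom at the far end of the molecule, so on this assay no step beyond the scatter is expected in either direction, with some chance that the removal of the chloro pushes the value toward the limit. The estimate for compound 4 is 55000 nM, within a range from 15000 nM to 128000 nM, which corresponds to an expected step of a 1.4-fold higher number from compound 3 to compound 4 (0.15 log units; within the scatter).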

Compound 4, half-maximal inhibitory concentration: 44900 nM
Compound 4: middle estimate off by 1.2-fold (0.09 log units), on the high side; measured number inside the range.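

In this assay, the change from 4-chlorophenyl to phenyl gives a 1.2-fold higher number from compound 3 to compound 4 (0.06 log units; within the scatter), so at this place, para to a large group, the chloro can give way to hydrogen without a step that can be told apart from ordinary repeat variation. The larger difference in this set lies with the whole (2-phenylethenyl)carbonyl group: with it in place of hydrogen the result is an at least 2.8-fold lower number from compound 1 to compound 4 (0.45 log units; beyond the scatter), and with it in place of hydroxy the result is an at least 2.8-fold lower number from compound 2 to compound 4 (0.45 log units; beyond the scatter). Both of these are minimum sizes only, since each starts from a limit rather than a number, and the step between the two compounds without this group cannot be read at all: the limit of > 128000 nM in this assay, at which 2 of the 4 values shown sit.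

The compounds shown leave open what other groups at this same place would do, such as a methoxy, an amine, a carboxylic acid or a bromo in place of the chloro. They also leave open whether the double bond of the 2-phenylethenyl group matters, which a saturated two-carbon chain in its place would test.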